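This account rests on a few compounds, and the source may have more. Where it says the series, first, only, none or still open, it means among the compounds named here.

Compound 1, `O=S(=O)(Nc1cc(-c2cnc3[nH]cc(-c4ccncc4)c3c2)cnc1Cl)c1ccccc1F`, gives > 10000 nM in a functional assay on NCI-H460 cells (Homo sapiens) for inhibition, read by sulforhodamine B assay, with a stated time of 72 h (on this read-out lower numbers stand for stronger inhibition of growth and higher numbers for weaker inhibition of growth), which is a limit of the assay rather than a number.
Compound 2, `O=S(=O)(Nc1cc(-c2cnc3[nH]cc(-c4ccccc4)c3c2)cnc1Cl)c1ccccc1`, gives > 10000 nM in this assay, also a limit.
Compound 3, `O=S(=O)(Nc1cc(-c2cnc3[nH]cc(-c4ccncc4)c3c2)cnc1Cl)c1ccc(F)cc1`, gives 6190 nM in this assay.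

Among the compounds with values here, compound 3 thus stands as the only measured number among the three; the other two are limits, as the limit of > 10000 nM in this assay, at which 2 of the 3 values shown sit, shows. Compound 4, `O=S(=O)(Nc1cc(-c2cnc3[nH]cc(-c4ccncc4)c3c2)cnc1Cl)c1ccccc1`, differs from compound 3 by hydrogen in place of fluoro on an aromatic carbon. Within the data shown here, only one measured step touches the ring on the sulfonyl sulfur: an at least 1.6-fold lower number from compound 1 to compound 3 (0.20 log units; that floor lies within the scatter). That step, bounded by a limit, offers little guidance. The expected step is a 1.5-fold higher number from compound 3 to compound 4 (0.16 log units; within the scatter), toward weaker growth inhibition or no change beyond the scatter. Compound 4 is therefore estimated at 9000 nM, with a range from 4000 nM to 25000 nM.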

Compound 4, concentration for 50% growth inhibition: 3900 nM
Beside the measured number, compound 4's estimate is 2.3-fold (0.36 log units) above it, and the stated range ends above it.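

In this assay, the fluoro on the 4-fluorophenyl group can be exchanged for hydrogen with a result that stays within the scatter: a 1.6-fold lower number from compound 3 to compound 4 (0.20 log units; within the scatter). Replacing 2-fluorophenyl with phenyl gives an at least 2.5-fold lower number from compound 1 to compound 4 (0.40 log units; beyond the scatter), and pyridin-4-yl in place of phenyl gives an at least 2.5-fold lower number from compound 2 to compound 4 (0.40 log units; beyond the scatter). Both of these steps start from a limit rather than a number: the limit of > 10000 nM in this assay, at which 2 of the 4 values shown sit.

The compounds shown leave open whether a methoxy group or an amine on the phenyl ring would move growth inhibition beyond the scatter. They also leave open how a piperazine ring would compare with pyridin-4-yl.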